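Swapping a hexyl chain for a fluorophenyl ring in a seizure model

A few compounds are considered here, and "the series" means these few. Any claim that something is new, unique, unknown or untested is made for them only; others in the source may bear on it.

Measured compounds:
Compound 1 `CCCCCOc1ccc2c(c1)C(=O)NCCO2` gives 56.8 mg/kg.
Compound 2 `CCCCCCCOc1ccc2c(c1)C(=O)NCCO2` gives 19 mg/kg.

Both compounds were tested in a functional assay on the whole organism with Mus musculus as the target, in the maximal electroshock model, with stated times of 30 min and 4 h; a higher number here means that more compound is needed for the effect, a lower number that less compound is needed. Of the two numbers, compound 2 has the lowest, and its nearest neighbour is compound 1: the step of a 3.0-fold lower number from compound 1 to compound 2 (0.48 log units; beyond the scatter) shows that lengthening the chain brought the dose down by a modest, real amount.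

The unmeasured compound 3 `O=C1NCCOc2ccc(OCc3ccccc3F)cc21` differs from compound 2 in one place: 2-fluorophenyl in place of hexyl on a saturated chain carbon bound to an oxygen on an aromatic ring. The hexyl chain is gone and a fluorine-bearing aromatic ring takes its place on the same carbon. Among the measured compounds shown here, the only measured step, from compound 1 to compound 2, concerns chain length alone; no measured pair shows what happens when a chain gives way to an aromatic ring, so it bears on this change only loosely. The group entering is of similar size to the one leaving, so a step of no more than modest size in this assay is expected, without a clear direction. Compound 3 is therefore estimated at 22 mg/kg, with a range from 8 mg/kg to 60 mg/kg, a step of a 1.2-fold higher number from compound 2 to compound 3 (0.06 log units; within the scatter).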

Compound 3, dose for half-maximal effect: 45.6 mg/kg
Estimate against measurement, compound 3: 2.1-fold (0.32 log units) below; the measured number falls inside the stated range.
By their numbers in this assay, from the lowest: compound 2; then compounds 3 and 1 (each within the scatter of the next).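

Among the compounds shown here, at this place, on a saturated chain carbon bound to an oxygen on an aromatic ring, the earlier compounds showed only the effect of chain length, whereas a ring can now be compared with a chain. In this assay, 2-fluorophenyl in place of hexyl did not match the chain, despite the close heavy-atom counts of the two groups, and more compound was needed (a 2.4-fold higher number from compound 2 to compound 3 (0.38 log units; beyond the scatter)). Against the shorter chain, the same ring gives a difference that lies within the scatter (a 1.2-fold lower number from compound 1 to compound 3 (0.10 log units; within the scatter)), so the dose advantage held by the hexyl compound does not carry over to this ring, and nothing measured here explains the difference between ring and chain.

On these data alone, whether a plain phenyl ring would give a number close to that of compound 3 stays open, so the part played by the fluorine cannot be separated from that of the ring. As far as these compounds go, it is also open whether a longer chain such as octyl would bring the number down further, or whether the fall with chain length ends at hexyl.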